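Trifluoromethyl to methoxy: an expectation for compound 4

The compounds below may be only part of what the source reports. "The series", "measured", "known", "first", "only" and "open" are said of these compounds alone.

Measured in a functional assay on A549 cells (Homo sapiens) for antiproliferative activity, read by MTT assay, with a stated time of 48 h; a lower number here means a stronger inhibitor, a higher number a weaker inhibitor:
compound 1 `Cc1ccc(/C=C/C(=O)Nc2nnc(-c3ccc(Cl)cc3)s2)cc1`: 1.25 ug/mL
compound 2 `COc1ccc(/C=C/C(=O)Nc2nnc(-c3ccc(C)cc3)s2)cc1`: 0.66 ug/mL
compound 3 `O=C(/C=C/c1ccc(C(F)(F)F)cc1)Nc1nnc(-c2ccc(Cl)cc2)s1`: 3.09 ug/mL

Compound 3 has the highest number of the three, making it the weakest inhibitor measured so far in this assay. The next structure, compound 4 `COc1ccc(/C=C/C(=O)Nc2nnc(-c3ccc(Cl)cc3)s2)cc1`, has methoxy in place of trifluoromethyl on an aromatic carbon, para to a large group: methoxy in place of trifluoromethyl on an aromatic carbon.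

Among the compounds with values here, only one measured step involves a single change at this kind of carbon: a 2.5-fold higher number from compound 1 to compound 3 (0.39 log units; beyond the scatter), a modest step that replaces methyl with trifluoromethyl. Within the data shown here, compound 1 therefore suggests that leaving trifluoromethyl could lower the number, although no measured step compares methoxy directly with either group. Compound 2 also carries methoxy and gives 0.66 ug/mL, the lowest number of the three. However, it differs from compound 4 at another place as well, so it offers only indirect support.

A modest move toward a lower number in this assay is therefore expected, similar to or slightly larger than the measured step. The expected change is a 2.8-fold lower number from compound 3 to compound 4 (0.45 log units; beyond the scatter). For compound 4, the estimated value is 1.1 ug/mL, with an expected range of 0.45 ug/mL to 2.5 ug/mL.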

Compound 4, half-maximal inhibitory concentration: 1.38 ug/mL
Compound 4: the middle estimate sits 1.3-fold (0.10 log units) below what was measured; low and high end bracket the measured number.
By their numbers in this assay, from the lowest: compounds 2, 1 and 4 (each within the scatter of the next, the first and the last beyond it); then compound 3.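

In this assay, the direct step of a 2.2-fold lower number from compound 3 to compound 4 (0.35 log units; beyond the scatter) shows that methoxy in place of trifluoromethyl on an aromatic carbon, para to a large group, gives a modest move to a lower number. With chloro held constant, methyl and methoxy at this carbon are not separated by a 1.1-fold higher number from compound 1 to compound 4 (0.04 log units; within the scatter), whereas trifluoromethyl in compound 3 stands apart from both compound 1 and compound 4, so among these three groups only trifluoromethyl gives a distinct reading here. With methoxy held constant, a 2.1-fold higher number from compound 2 to compound 4 (0.32 log units; beyond the scatter) shows that chloro in place of methyl at the other substituted aromatic carbon also shifts the number by a modest step, so this second place matters as well.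

No measurement available here explains the gap between trifluoromethyl and the other two groups. Still open, from the compounds shown here alone, is how an amine, a hydroxyl or a carboxylic acid on the same aromatic carbon would read against methoxy and methyl, and whether the effect of the change from chloro to methyl carries over when trifluoromethyl replaces methoxy.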